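A few compounds are considered here, and "the series" means these few. Any claim that something is new, unique, unknown or untested is made for them only; others in the source may bear on it.

Three compounds of the series carry results in a functional assay for antagonist activity at transient receptor potential cation channel subfamily V member 1 (Rattus norvegicus); a higher number here means a weaker inhibitor, a lower number a stronger inhibitor. Compound 1 `Cc1cccnc1-c1ccc(C(=O)Nc2ccc(Cl)cc2)cc1` gives 2020 nM. Compound 3 `O=C(Nc1ccc(C(F)(F)F)cc1)c1ccc(-c2ncccc2C(F)(F)F)cc1Cl` gives 2400 nM, and this value and that of compound 1 lie within the scatter of one another. Compound 2 `CC(C)(C)c1ccc(NC(=O)c2ccc(-c3ncccc3-c3nn[nH]n3)cc2)cc1` gives only a limit of the assay, > 4000 nM. This is the limit of > 4000 nM in this assay, at which 1 of the 3 values shown sits.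

Compound 4 `COc1cc(-c2ncccc2C(F)(F)F)ccc1C(=O)Nc1ccc(C(F)(F)F)cc1` is not yet measured. It differs from compound 3 by methoxy in place of chloro on an aromatic carbon. For the measured compounds named here, no pair of measured compounds covers this change, so no measured step guides the expectation. The change from compound 3 to compound 4 is expected to be small, a 1.3-fold higher number from compound 3 to compound 4 (0.10 log units; within the scatter), with no direction claimed beyond the scatter. Compound 4 is therefore expected near 3000 nM, in the range 1200 nM to 8000 nM.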

Compound 4, half-maximal inhibitory concentration: 1040 nM
The estimate for compound 4 lay 2.9-fold (0.46 log units) above the measured number; the whole stated range lies above it.
By their numbers in this assay, from the lowest: compounds 4, 1 and 3 (each within the scatter of the next, the first and the last beyond it). At a limit, above all of these: compound 2.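

Methoxy in place of chloro on this aromatic carbon, ortho to a large group, gives a 2.3-fold lower number from compound 3 to compound 4 (0.36 log units; beyond the scatter) in this assay. For the compounds shown here, this is the first single-place step measured, and it shows that this position can move the number beyond the scatter, towards stronger inhibition. Nothing measured here accounts for the step. On these data alone, whether a hydroxyl or an ethoxy at this position would give a still lower number stays open. Also open, as far as these compounds go, is whether the step holds when the 3-(trifluoromethyl)pyridin-2-yl group is replaced.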